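The source may hold more compounds than are shown below. What is called first, only, known or untested is meant among the compounds shown, and "the series" means these compounds.

In a functional assay on VCaP cells (Homo sapiens) for antiproliferative activity, read by propidium iodide staining, with a stated time of 96 h (on this read-out lower numbers stand for stronger inhibition and higher numbers for weaker inhibition), compound 1 `CC(O)(COc1cccc(C(F)(F)F)c1)C(=O)Nc1ccc(S(F)(F)(F)(F)F)cc1` gives 24700 nM, while compound 2 `CC(O)(COc1ccccc1C(F)(F)F)C(=O)Nc1ccc(S(F)(F)(F)(F)F)cc1` gives 3100 nM, the lower of the two numbers and so the stronger inhibition measured so far. The next compound, compound 3 `CC(O)(COc1ccccc1OC(F)(F)F)C(=O)Nc1ccc(S(F)(F)(F)(F)F)cc1`, changes one group of compound 2: trifluoromethoxy in place of trifluoromethyl on an aromatic carbon. This places trifluoromethoxy in place of trifluoromethyl on an aromatic carbon, ortho to a large group. Among the compounds with values here, only one measured step bears on this change, an 8.0-fold lower number from compound 1 to compound 2 (0.90 log units; beyond the scatter). That modest step relocates the trifluoromethyl group and does not replace it, so it gives no direct measure of this exchange. With the new group at the same ring position, no step beyond the scatter is expected in this assay, and no direction is favoured with confidence. The estimated change is a 1.1-fold higher number from compound 2 to compound 3 (0.05 log units; within the scatter). For compound 3, the expected value is 3500 nM, with an estimated range of 1200 nM to 10000 nM.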

Compound 3, half-maximal inhibitory concentration: 9700 nM
Estimate against measurement, compound 3: 2.8-fold (0.44 log units) below; the measured number falls inside the stated range.
By their numbers in this assay, from the lowest: compound 2; then compound 3; then compound 1.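

In this assay, the group on this aromatic carbon, ortho to a large group, is not interchangeable: trifluoromethoxy in place of trifluoromethyl gives a 3.1-fold higher number from compound 2 to compound 3 (0.50 log units; beyond the scatter). The earlier step only relocated the trifluoromethyl group, whereas this one keeps the place fixed and shows that the read-out also responds to the identity of the group there, with the weaker inhibition coming from trifluoromethoxy. Nothing available explains why this exchange weakens inhibition.

The compounds shown leave open how a nitrile, a chlorine or a methyl group would compare with trifluoromethyl on this same aromatic carbon. They also leave open whether trifluoromethoxy would produce a similar step at the ring position that the trifluoromethyl group occupies in compound 1.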